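The source may hold more compounds than are shown below. What is called first, only, known or untested is meant among the compounds shown, and "the series" means these compounds.

Measured compounds:
Compound 1, `Fc1ccccc1-c1ccc2[nH]ncc2c1`: 3950 nM
Compound 2, `CC(C)(C)c1ccccc1-c1ccc2[nH]ncc2c1`: 3400 nM
Compound 3, `CCc1cc2[nH]ncc2cc1-c1ccccc1C(F)(F)F`: 50 nM

All three compounds were tested in an assay on CHO-TREX cells for antagonist activity at transient receptor potential cation channel subfamily A member 1 (Homo sapiens), read by FLIPR and calcium flux, with a stated time of 10 min; on this read-out lower numbers stand for stronger inhibition and higher numbers for weaker inhibition. Compound 3 gives the lowest number of the three, and its gap to compound 2, the nearest, and to compound 1, the furthest, both lie beyond the scatter of repeated measurement, so compound 3 is the strongest inhibitor of this set.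

Compound 4, `CCOc1cc2[nH]ncc2cc1-c1ccccc1C(F)(F)F`, is the next compound, not yet measured. It differs from compound 3 in one place: ethoxy in place of ethyl on an aromatic carbon.

Only one measured step exists among these compounds, a 1.2-fold lower number from compound 1 to compound 2 (0.07 log units; within the scatter), and it concerns the other ring of the shared core, where fluoro gave way to tert-butyl; that step stayed within the scatter. Going by the values given here, it does not touch the place that changes between compound 3 and compound 4, so no measured step bears directly on the present change. With nothing in the data pointing either way, the expected step is a 1.6-fold higher number from compound 3 to compound 4 (0.20 log units; within the scatter), that is, no change beyond the scatter. Compound 4 is therefore estimated at 80 nM in this assay, with a range from 20 nM to 320 nM.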

Compound 4, half-maximal inhibitory concentration: 39 nM
For compound 4 the middle estimate is 2.1-fold (0.31 log units) above the measured one, within the range that was stated.
By their numbers in this assay, from the lowest: compounds 4 and 3 (each within the scatter of the next); then compounds 2 and 1 (each within the scatter of the next).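

In this assay, going by these compounds alone, the exchange of ethyl for ethoxy on this aromatic carbon, ortho to a large group, gives the first measured step at this position (a 1.3-fold lower number from compound 3 to compound 4 (0.11 log units; within the scatter)). The two compounds therefore cannot be told apart on this read-out: the entering oxygen brings one hydrogen-bond acceptor and one more heavy atom, yet the number stays within the scatter, something the earlier step on the other ring could not show. Nothing measured here gives a reason for this outcome.

From the compounds shown here alone, only these two groups have been compared at this position, so it remains open whether the same flat result would hold for an amine, a carboxylic acid, or a longer chain such as propoxy, and whether ethoxy would behave the same way with a group other than trifluoromethyl on the other ring. Compound 3 and compound 4 each differ from compound 1 and compound 2 in more than one place, so what any group at this position adds relative to the plain shared core also stays unresolved.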